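Pyrimidinyl in place of methyloxazolyl on an imidazoline scaffold

The source may hold more compounds than are shown below. What is called first, only, known or untested is meant among the compounds shown, and "the series" means these compounds.

Compound 1 `c1ccc(-c2cnco2)c(NCC2=NCCN2)c1`: 17.4 nM
Compound 2 `Cc1nc(-c2ccccc2NCC2=NCCN2)co1`: 324 nM

In a functional assay for activation of Alpha-1A adrenergic receptor (Homo sapiens), read by calcium flux (on this read-out higher numbers stand for an effect only at larger amounts of compound and lower numbers for an effect already at smaller amounts), compound 2 gives 324 nM, the highest of the two numbers; its nearest neighbour is compound 1, a 19-fold higher number from compound 1 to compound 2 (1.27 log units; beyond the scatter). Compound 3 `c1cnc(-c2ccccc2NCC2=NCCN2)nc1` differs from compound 2 only in one place: pyrimidin-2-yl in place of 2-methyl-1,3-oxazol-4-yl on an aromatic carbon. For the measured compounds named here, the one measured step bears on it directly, because a 19-fold higher number from compound 1 to compound 2 (1.27 log units; beyond the scatter) shows that the ring at this position moves the number strongly. A moderate step down, toward compound 1, is therefore expected: a 3.2-fold lower number from compound 2 to compound 3 (0.51 log units; beyond the scatter). For compound 3 the estimate is 100 nM, between 20 nM and 600 nM.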

Compound 3, half-maximal effective concentration: 10 nM
The estimate for compound 3 lay 10-fold (1.00 log units) above the measured number, outside the stated range (below it).
By their numbers in this assay, from the lowest: compounds 3 and 1 (each within the scatter of the next); then compound 2.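

In this assay, pyrimidin-2-yl in place of 2-methyl-1,3-oxazol-4-yl gives a large drop (a 32-fold lower number from compound 2 to compound 3 (1.51 log units; beyond the scatter)), so this position accepts a six-membered aromatic ring and the high number of compound 2 does not extend to every replacement of the 1,3-oxazol-5-yl group. Pyrimidin-2-yl and 1,3-oxazol-5-yl cannot be told apart here (a 1.7-fold lower number from compound 1 to compound 3 (0.24 log units; within the scatter)). Nothing available explains these differences.

From the compounds shown here alone, it remains open whether the methyl group or the point of attachment of the ring sets compound 2 apart, a question that an unmethylated 1,3-oxazol-4-yl group would address. Going by these compounds, how a phenyl or pyridin-2-yl group would read at this position is also open.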